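The source may hold more compounds than are shown below. What is called first, only, known or untested is meant among the compounds shown, and "the series" means these compounds.

In a toxicity assay on cells (Erythrocyte, Mus musculus) for activation, read by spectrophotometry and hemolysis, with a stated time of 30 min (on this read-out higher numbers stand for an effect only at larger amounts of compound and lower numbers for an effect already at smaller amounts), the measured compounds stand as follows:

- compound 1 `Clc1ccc(/C=N/Nc2nc3ccccc3s2)cc1` gives the limit > 200 ug/mL
- compound 2 `O=C(O)c1ccccc1/C=N/Nc1nc2ccccc2s1` gives the limit > 200 ug/mL
- compound 3 `Clc1ccc(/C=N/Nc2nc3ccccc3s2)c(Cl)c1` gives the limit > 200 ug/mL

Each of these entries is a limit of the assay and not a number. Compound 1 therefore has no exact place on the scale and stands at the limit of > 200 ug/mL in this assay, at which 3 of the 3 values shown sit.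

The unmeasured compound 4 `C(=N/Nc1nc2ccccc2s1)\c1ccc(-c2ccccn2)cc1` differs from compound 1 in one place (pyridin-2-yl in place of chloro on an aromatic carbon), with pyridin-2-yl in place of chloro on an aromatic carbon, para to a large group. Among the compounds with values here, the only measured step that bears on this is a step that the two limits leave unreadable from compound 1 to compound 3, where a chloro takes the place of hydrogen on an aromatic carbon. It offers no size to carry over, and it is a different change. With all three measured compounds at the same limit, no step beyond the scatter is expected in this assay, and another limit is the likeliest result. The expected step is a number no higher from compound 1 to compound 4 (the limit leaves the size open). Compound 4 is estimated at 200 ug/mL, with an expected range from 100 ug/mL to 400 ug/mL.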

Compound 4, half-maximal effective concentration: > 200 ug/mL
Compound 4 was reported as a limit (the forecaster's own chance of this, stated with the estimate: 80%); the middle value sits exactly at the limit.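

The step from compound 1 to compound 4 cannot be read, since each of the two compounds gives only a limit in this assay and not a number: the limit of > 200 ug/mL in this assay, at which 4 of the 4 values shown sit.

The compounds shown leave open at what amount any of them would give an effect, and whether pyridin-2-yl in place of chloro alters that amount.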